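From pentyl to pentan-3-yl on a shared core

The source may report more compounds than this note shows. Statements on the series, on what has been measured and on what is new or still open speak of the compounds shown alone.

- compound 1 `CNc1nc(SC)nc2ncccc12`: 2920 nM
- compound 2 `CCCCCNc1nc(SC)nc2ncccc12`: 650 nM
- compound 3 `CSc1nc(NCC(C)C)c2cccnc2n1`: 540 nM

In a functional assay (Nicotiana tabacum) (a lower number here means a stronger inhibitor, a higher number a weaker inhibitor), compound 2 stands well clear of the highest number, with a 4.5-fold lower number from compound 1 to compound 2 (0.65 log units; beyond the scatter). Its value cannot be separated from the remaining one, with a 1.2-fold lower number from compound 2 to compound 3 (0.08 log units; within the scatter).

Compound 4 `CCC(CC)Nc1nc(SC)nc2ncccc12` carries pentan-3-yl in place of pentyl on a nitrogen on an aromatic ring. The larger measured steps, a 4.5-fold lower number from compound 1 to compound 2 (0.65 log units; beyond the scatter) and a 5.4-fold lower number from compound 1 to compound 3 (0.73 log units; beyond the scatter), both add carbon to the chain, whereas compound 4 has the same atoms as compound 2. They therefore offer little guidance here. The closest guide is a 1.2-fold lower number from compound 2 to compound 3 (0.08 log units; within the scatter), which shows one change of chain shape leaving the number within the scatter. For the measured compounds named here, no measured compound has a chain branched at the carbon bound to the nitrogen, so this change remains untested and the direction is uncertain. The expected change is a 1.1-fold lower number from compound 2 to compound 4 (0.03 log units; within the scatter), with nothing beyond the scatter anticipated. For compound 4 the estimated value is 600 nM, with an expected range of 250 nM to 1500 nM.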

Compound 4, half-maximal inhibitory concentration: 2720 nM
Estimate against measurement, compound 4: 4.5-fold (0.66 log units) below, outside the stated range (above it).
By their numbers in this assay, from the lowest: compounds 3 and 2 (each within the scatter of the next); then compounds 4 and 1 (each within the scatter of the next).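

In this assay, for the compounds shown here, the same atoms joined differently on a nitrogen on an aromatic ring give a 4.2-fold higher number from compound 2 to compound 4 (0.62 log units; beyond the scatter), whereas the one earlier change of chain shape, a 1.2-fold lower number from compound 2 to compound 3 (0.08 log units; within the scatter), stayed within the scatter, so the shape of the chain at this position can matter as well as its size. Pentan-3-yl also gives a 5.0-fold higher number from compound 3 to compound 4 (0.70 log units; beyond the scatter), while against methyl it shows only a 1.1-fold lower number from compound 1 to compound 4 (0.03 log units; within the scatter), so the lower numbers seen with pentyl and isobutyl do not extend to every larger chain on this nitrogen. Nothing available explains why this rearrangement of the chain raises the number.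

On these data alone, compound 4 alone carries a chain branched at the carbon bound to the nitrogen, so it remains open whether that branch point decides the result. Isopropyl or cyclopentyl on the same nitrogen could show whether the higher number extends beyond pentan-3-yl.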